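Swapping a Pyridine for a Methyl on the Anilide

A few compounds are considered here, and "the series" means these few. Any claim that something is new, unique, unknown or untested is made for them only; others in the source may bear on it.

Of the compounds shown here, three sharing one core have been measured in a functional assay on NCI-H460 cells (Homo sapiens) for antiproliferative activity, read by CCK-8 assay, with a stated time of 72 h, tested at 2 uM; on this read-out lower numbers stand for a weaker effect and higher numbers for a stronger effect at the one concentration tested. Compound 1 `Nc1ccccc1NC(=O)/C=C/c1ccc(Cn2cnc3c(NCc4ccccc4)nc(Cl)nc32)cc1` gives 4.62%. Compound 2 `Nc1ccccc1NC(=O)c1ccc(Cn2cnc3c(Nc4ccc(-c5ccccn5)cc4)nc(Cl)nc32)cc1` gives 18.1%. Compound 3 `CCC(C)n1cnc2c(NCc3ccc(C(=O)Nc4ccccc4N)cc3)nc(Cl)nc21` gives 47.3%.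

Compound 2 stands second highest of the three numbers. Its nearest neighbour is compound 1, whose number is lower by a gap that lies beyond the usual scatter, and the furthest is compound 3, whose number is higher by a gap that also lies beyond the scatter. Compound 2 thus sits between a weak and a clearly stronger result.

The unmeasured compound 4 `Cc1ccc(Nc2nc(Cl)nc3c2ncn3Cc2ccc(C(=O)Nc3ccccc3N)cc2)cc1` differs from compound 2 in a single place: methyl in place of pyridin-2-yl on an aromatic carbon. The phenyl ring carrying the change keeps its position in the molecule; only the pyridin-2-yl is exchanged for methyl.

Among the measured compounds shown here, no measured pair shows this exact exchange, so its size cannot be read from the data. A step of modest size is expected in this assay, more likely downward than upward, but one that may well stay within the scatter. Compound 4 is therefore estimated to give 15%, with a range from 5% to 35%, an expected step of a number 3.1 percentage points lower from compound 2 to compound 4 (within the scatter).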

Compound 4, a percentage reported as inhibition, at one concentration (the size of the read-out at that concentration, not a potency): 67.3%
Compound 4: the middle estimate sits 52.3 percentage points below what was measured; measured number above the stated range.
By their numbers in this assay, from the lowest: compound 1; then compound 2; then compound 3; then compound 4.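

In this assay, putting methyl in place of pyridin-2-yl on this aromatic carbon gives a number 49.2 percentage points higher from compound 2 to compound 4 (beyond the scatter), so this position strongly influences the result. Among the compounds shown here, no earlier compound could show this. None of them formed a matched pair. The exchange replaces 6 heavy atoms, including a six-membered aromatic ring with a nitrogen, with 1 heavy atom, and the effect at the one concentration tested rises rather than falls; for this pair, then, the pyridin-2-yl ring is not needed for the antiproliferative effect, and the much smaller methyl serves better. For the compounds shown here, nothing available explains why this single exchange moves the number so far.

This one pair cannot separate the loss of the ring as a whole from the loss of its nitrogen, since the two leave together, and a plain phenyl at the same place would be needed to tell them apart. It also leaves open how a lone hydrogen, an ethyl, a methoxy group or an amine would behave here, and whether the same step holds in other cell lines or across a range of concentrations.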